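One aromatic ring swapped for another on a shared core

The source may report more compounds than this note shows. Statements on the series, on what has been measured and on what is new or still open speak of the compounds shown alone.

Values measured in a physicochemical assay for solubility, read by LC-MS, in phosphate buffer, with a stated time of 24 h, at pH 7.4 (on this read-out higher numbers stand for higher solubility and lower numbers for lower solubility), for three compounds:
- Compound 1 `Cc1nccn1-c1cnc(NCc2c(F)ccc3c2CCO3)c2cn[nH]c(=O)c12` gives 7000 nM
- Compound 2 `CC(=O)N1CCC(c2cnc(NCc3c(F)ccc4c3CCO4)c3cn[nH]c(=O)c23)CC1` gives < 2000 nM as a limit of the assay and not a number
- Compound 3 `Cc1ncc(-c2cnc(NCc3c(F)ccc4c3CCO4)c3cn[nH]c(=O)c23)n1C` gives 15000 nM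

Of the two true numbers, the higher belongs to compound 3. The gap is small but beyond the usual scatter, and the data show a 2.1-fold higher number from compound 1 to compound 3 (0.33 log units; beyond the scatter) here.

Compound 4 `Cc1ncccc1-c1cnc(NCc2c(F)ccc3c2CCO3)c2cn[nH]c(=O)c12` keeps the shared core and changes one group, as 2-methylpyridin-3-yl in place of 1,2-dimethyl-1H-imidazol-5-yl on an aromatic carbon shows. Here 2-methylpyridin-3-yl comes in place of 1,2-dimethyl-1H-imidazol-5-yl on an aromatic carbon.

For the measured compounds named here, no measured step brings in this six-membered aromatic ring, so the guidance is indirect. The closest guide is the exchange of one imidazole-bearing group for another, which gave a 2.1-fold higher number from compound 1 to compound 3 (0.33 log units; beyond the scatter) as a modest change. As far as these compounds go, the exchange involving 1-acetylpiperidin-4-yl gave an at least 7.5-fold higher number from compound 2 to compound 3 (0.87 log units; beyond the scatter) as a larger step, but its true size is unknown, as the limit of < 2000 nM in this assay, at which 1 of the 3 values shown sits, marks. Since compound 3 at 15000 nM holds the top number, a modest fall is more likely than a rise. The expected change is a 2.1-fold lower number from compound 3 to compound 4 (0.33 log units; beyond the scatter) in this assay as an estimate. The estimate for compound 4 is 7000 nM with an expected range of 2500 nM to 18000 nM overall.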

Compound 4, solubility: < 2000 nM
Compound 4 gave a limit, no number; the forecaster's own chance of this, stated with the estimate: 10%; at least 3.5-fold (0.54 log units) between middle value and limit.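

In this assay, placing 2-methylpyridin-3-yl on this aromatic carbon in place of 1,2-dimethyl-1H-imidazol-5-yl gives an at least 7.5-fold lower number from compound 3 to compound 4 (0.87 log units; beyond the scatter) and so shows that the choice of aromatic ring here can matter more than the modest step between the two imidazole-bearing compounds suggested. The same group also falls short of 2-methyl-1H-imidazol-1-yl, with an at least 3.5-fold lower number from compound 1 to compound 4 (0.54 log units; beyond the scatter) as the step, so among the three aromatic groups shown on this carbon, only the two five-membered rings give true numbers. Compound 4 gives a limit of the assay and not a number, so both steps have no known full size and the step between compound 2 and compound 4 cannot be read: the limit of < 2000 nM in this assay, at which 2 of the 4 values shown sit.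

The compounds shown cannot separate the change in ring size from the change in the count of ring nitrogens, and a five-membered ring with one nitrogen, such as an N-methylpyrrol-2-yl group, would bear on that question. As far as these compounds go, it also remains open whether a six-membered aromatic ring can do better at this position when it carries a dimethylamino group or a morpholine.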